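Working notes: compound 3 swaps benzyl for an amide-bearing chain

This account rests on a few compounds, and the source may have more. Where it says the series, first, only, none or still open, it means among the compounds named here.

For the measured compounds named here, the two measured members were both tested in an assay on MCF7 cells for inhibition of Serine-protein kinase ATM (Homo sapiens), read by immunofluorescence, with a stated time of 1 h; on this read-out higher numbers stand for weaker inhibition and lower numbers for stronger inhibition. Compound 1 `COc1cc2ncnc(-n3nc(-c4cccnc4)nc3N)c2cc1OC` gives 15000 nM there. Compound 2 `COc1cc2ncnc(-n3nc(-c4ccccn4)nc3N)c2cc1OCc1ccccc1` gives 8600 nM in this assay, the lower of the two numbers, although the gap to compound 1 lies within the usual scatter, so neither compound can be called the stronger inhibitor on these data alone. Going by the values given here, no single-change step between the measured compounds is recorded, so there is no directly read step to lean on.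

Compound 3 `COc1cc2ncnc(-n3nc(-c4ccccn4)nc3N)c2cc1OCCCNC(=O)C(F)(F)F` is the next member to be measured in this assay. Relative to compound 2 the change is 2-(((trifluoromethyl)carbonyl)amino)ethyl in place of phenyl on a saturated chain carbon bound to an oxygen on an aromatic ring. Among the compounds with values here, with no measured step available at this position, the expectation for the step from compound 2 to compound 3 is one of roughly no change beyond the scatter, perhaps a modest loss, with a wide range, estimated as a 1.2-fold higher number from compound 2 to compound 3 (0.07 log units; within the scatter). Accordingly compound 3 is expected to give about 10000 nM in this assay, within a range from 3500 nM to 30000 nM.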

Compound 3, half-maximal inhibitory concentration: 2900 nM
Compound 3: the middle estimate sits 3.4-fold (0.54 log units) above what was measured, and the stated range ends above it.
By their numbers in this assay, from the lowest: compound 3; then compounds 2 and 1 (each within the scatter of the next).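

In this assay, for the compounds shown here, the change from phenyl to 2-(((trifluoromethyl)carbonyl)amino)ethyl on a saturated chain carbon bound to an oxygen on an aromatic ring gives a 3.0-fold lower number from compound 2 to compound 3 (0.47 log units; beyond the scatter) and is the only readable step so far. It shows that, for this pair, inhibition at this position does not depend on keeping the six-membered aromatic ring: the open chain, with no ring and with one hydrogen-bond donor and one hydrogen-bond acceptor, gives a modest gain rather than a loss. No measurement at hand bears on the origin of this gain.

The compounds shown leave open which part of the new chain goes with the step, since the amide, the trifluoromethyl and the chain itself enter together; a 3-aminopropyl group, an acetyl amide in place of the trifluoromethyl amide or a longer chain would begin to separate them. Going by these compounds alone, compound 1 differs from compound 2 and compound 3 in more than one place, so no step to it can be read, and whether the gain carries over to other substituents on the shared core remains open.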